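Anilino series on a shared core: the ethyl step

This account rests on a few compounds, and the source may have more. Where it says the series, first, only, none or still open, it means among the compounds named here.

Compound 1 `COc1cccc(NC2=CC(=O)c3c(nc4n3[C@H]3OC[C@@H](O)[C@H]3OC4)C2=O)c1` gives > 8000 nM in a functional assay on HeLa cells (Homo sapiens) for inhibition, read by sulforhodamine B assay; a higher number here means a weaker inhibitor, a lower number a stronger inhibitor; this is a limit of the assay, not a number.
Compound 2 `CCOc1ccccc1NC1=CC(=O)c2c(nc3n2[C@H]2OC[C@@H](O)[C@H]2OC3)C1=O` gives 8300 nM in this assay.
Compound 3 `O=C1C(Nc2ccccc2)=CC(=O)c2c1nc1n2[C@H]2OC[C@@H](O)[C@H]2OC1` gives > 8000 nM in this assay; this is again a limit of the assay, not a number.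

Compound 3 therefore stands at the limit, and only compound 2 carries a number at all; the limit of > 8000 nM in this assay, at which 2 of the 3 values shown sit, marks how the shown values sit. Every measured step in this assay is consequently unreadable: a step that the two limits leave unreadable from compound 1 to compound 3, a step that the limit leaves unreadable from compound 2 to compound 3 and a step that the limit leaves unreadable from compound 1 to compound 2. The series gives no direction in which a substituent on the anilino ring moves the read-out.

Compound 4 `CCc1ccc(NC2=CC(=O)c3c(nc4n3[C@H]3OC[C@@H](O)[C@H]3OC4)C2=O)cc1` carries the change (ethyl in place of hydrogen on an aromatic carbon).

Among the measured compounds shown here, no measured step bears readably on it. Methoxy, ethoxy and hydrogen on that ring all leave the compounds at or close to the limit in this assay, so a readable gain from an ethyl group is not expected here; the expected step that the limit leaves unreadable from compound 3 to compound 4 is none beyond the scatter, with a fair chance that compound 4 again returns only a limit. Compound 4 is estimated at 9000 nM, with a range from 3000 nM to 30000 nM.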

Compound 4, half-maximal inhibitory concentration: 6510 nM
For compound 4 the middle estimate is 1.4-fold (0.14 log units) above the measured one, within the range that was stated.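

With ethyl on an aromatic carbon, para to a large group, compound 4 joins compound 2 as the only compounds shown that carry a number rather than a limit in this assay, but the change itself yields no step beyond the scatter: an at least 1.2-fold lower number from compound 3 to compound 4 (0.08 log units; that floor lies within the scatter) is the reading here, and only a floor can be given. Compared with the two substituted anilino compounds, the result is the same, with a 1.3-fold lower number from compound 2 to compound 4 (0.11 log units; within the scatter) and an at least 1.2-fold lower number from compound 1 to compound 4 (0.08 log units; that floor lies within the scatter), so 4-ethylphenyl is not separated from 2-ethoxyphenyl or 3-methoxyphenyl on the amine nitrogen. All four anilino compounds therefore remain at or close to one limit, and a direction for substituents on this ring still cannot be read: the limit of > 8000 nM in this assay, at which 2 of the 4 values shown sit.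

The compounds shown leave open whether any group at this place can produce a step beyond the scatter in this assay. A longer chain such as butyl, an amine or a carboxylic acid on the same aromatic carbon would test this, and a value well clear of the limit would be needed before any trend on the ring could be stated.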